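The source may hold more compounds than are shown below. What is called first, only, known or untested is meant among the compounds shown, and "the series" means these compounds.

Compound 1 `CC(C)[C@@H](NC(=O)/C=C/c1ccncc1-c1ccc2ccccc2c1)C(=O)O` carries a 1-carboxy-2-methylpropyl group on its amide nitrogen, joined through an unsaturated linker to the shared core. In an assay on a protein complex for inhibition of CDK8/Cyclin C (Homo sapiens), with a stated time of 1 h (on this read-out higher numbers stand for weaker inhibition and lower numbers for stronger inhibition), compound 1 has "not determined" (no result reported) as its result, so it cannot be placed on the numbers at hand; it stands without a value of its own. Two relatives set the scale. Among the compounds with values here, compound 2 `Cn1ccc2cc(-c3cnccc3/C=C/C(=O)O)ccc21` gives 26.8 nM in this assay, and compound 3 `CNC(=O)/C=C/c1ccncc1-c1ccc2c(cnn2C)c1` gives 86.7 nM in this assay; both values show that this family reaches strong inhibition on this read-out, though the two compounds differ in more than one place and no single step links them.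

Compound 4 `CNC(=O)/C=C/c1ccncc1-c1ccc2ccccc2c1` differs from compound 1 by methyl in place of 1-carboxy-2-methylpropyl on an amide-type nitrogen. Within the data shown here, with no number for compound 1, no step can be sized or given a direction; the expectation rests on the measured relatives. Because compound 3 gives 86.7 nM with the same methylamino amide end, compound 4 is expected to give about 60 nM, most likely between 15 nM and 250 nM.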

Compound 4, half-maximal inhibitory concentration: 12.4 nM
For compound 4 the middle estimate is 4.8-fold (0.68 log units) above the measured one; measured number outside the range, below it.
By their numbers in this assay, from the lowest: compound 4; then compound 2; then compound 3.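

No step can be read from the result for compound 4, as neither compound 1 nor compound 2 or compound 3 gives a measured pair differing in one place. The compounds shown leave open how 1-carboxy-2-methylpropyl and methyl on the amide-type nitrogen compare in this assay on this core. No evidence at hand bears on this result.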